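This account rests on a few compounds, and the source may have more. Where it says the series, first, only, none or still open, it means among the compounds named here.

Measured so far in an assay on HEK293 cells for agonist activity at Bile acid receptor (Homo sapiens), read by a luciferase reporter; a higher number here means that more compound is needed for the effect, a lower number that less compound is needed:
compound 1, `CC(C)OC(=O)C1CN(C(=O)C2CCCCC2)CC(C)(C)c2cc(C#N)[nH]c21`, gives 1900 nM;
compound 2, `CC(C)OC(=O)C1CN(C(=O)c2ccc(C#N)cc2)CC(C)(C)c2cc(C#N)[nH]c21`, gives 5700 nM.

Compound 2 stands at the higher of the two numbers in this assay. Among the measured compounds shown here, the only measured step, a 3.0-fold higher number from compound 1 to compound 2 (0.48 log units; beyond the scatter), is beyond the scatter and modest in size. Compound 3, `CC(C)OC(=O)C1CN(C(=O)c2ccc(Cl)cc2)CC(C)(C)c2cc(C#N)[nH]c21`, has not yet been measured. It differs from compound 2 in one place: chloro in place of cyano on an aromatic carbon. For the measured compounds named here, no measured step swaps one group for another on the aromatic ring of compound 2; the step from compound 1 to compound 2 replaces the whole group on the carbonyl carbon, and so bears on the present change only loosely. It shows that this part of the molecule can shift the number by a modest amount, but it offers no direction for a chloro in place of a cyano. The step is therefore expected to be small, a 1.4-fold lower number from compound 2 to compound 3 (0.15 log units; within the scatter), within or only slightly beyond the scatter. For compound 3 in this assay the estimate is 4000 nM, with a range from 1500 nM to 11000 nM.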

Compound 3, half-maximal effective concentration in the Bile acid receptor assay: 4100 nM
Estimate against measurement, compound 3: 1.0-fold (0.01 log units) below, within the range that was stated.
By their numbers in the Bile acid receptor assay, from the lowest: compound 1; then compounds 3 and 2 (each within the scatter of the next).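

The swap of 4-cyanophenyl to 4-chlorophenyl gives a direct reading of this position: in the Bile acid receptor assay it produces a 1.4-fold lower number from compound 2 to compound 3 (0.14 log units; within the scatter), so the two groups are not told apart on this read-out. Also in the Bile acid receptor assay, the comparison with the saturated ring gives a 2.2-fold higher number from compound 1 to compound 3 (0.33 log units; beyond the scatter), which places the 4-chlorophenyl compound, like the 4-cyanophenyl compound, on the higher side of the cyclohexyl compound, and neither of the two compounds with an aromatic ring goes against this. In a physicochemical assay for solubility, at pH 7.4 (on this read-out lower numbers stand for lower solubility and higher numbers for higher solubility), compound 2 gives 21 ug/mL and compound 3 gives 5 ug/mL. The same change does register in this different measurement, where chloro in place of cyano lowers solubility in the physicochemical assay: the measured solubility of compound 2, 21 ug/mL, and of compound 3, 5 ug/mL, a 4.2-fold lower number (0.62 log units; beyond the scatter)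

The compounds shown place only cyano and chloro at this position, which leaves open whether a methoxy group, a fluoro group or an amine there would move the number in the Bile acid receptor assay beyond the scatter. On these data alone, it also remains open whether any such group, or a carboxylic acid, would keep the number in the Bile acid receptor assay where it stands while giving a higher number in the physicochemical assay.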